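Flipping the stereocentres of a cinnamate-bearing bicyclic lactone

A few compounds are considered here, and "the series" means these few. Any claim that something is new, unique, unknown or untested is made for them only; others in the source may bear on it.

Measured compounds:
- Compound 1 `O=C1C[C@H]2O[C@H]([C@@H](O)c3ccccc3)[C@H](O)[C@H]2O1`: 18600 nM
- Compound 2 `O=C(/C=C/c1ccccc1)O[C@@H](c1ccccc1)[C@@H]1O[C@H]2CC(=O)O[C@H]2[C@@H]1O`: 15700 nM
- Compound 3 `O=C1C[C@@H]2O[C@@H]3[C@@H](O[C@H]3c3ccccc3)[C@@H]2O1`: 28500 nM

All three were tested in a functional assay on Jurkat cells (Homo sapiens) for cytotoxicity, read by MTT assay, with a stated time of 72 h; a lower number here means a stronger inhibitor, a higher number a weaker inhibitor. Compound 2 gives the lowest number of the three, but its gaps to compound 1 and to compound 3 both fall within the usual scatter, so no ranking among them can be drawn.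

Compound 4 `O=C(/C=C/c1ccccc1)O[C@H](c1ccccc1)[C@H]1O[C@@H]2CC(=O)O[C@@H]2[C@H]1O` keeps every atom and bond of compound 2 and changes only the configuration: the two compounds have the same atoms and bonds and differ only in configuration as drawn: 5 of 6 stereo elements differ; a stereocentre at a saturated chain carbon is drawn S in compound 2 and R in compound 4; a stereocentre at a saturated ring carbon is drawn R in compound 2 and S in compound 4; a stereocentre at a saturated ring carbon is drawn S in compound 2 and R in compound 4; a stereocentre at a saturated ring carbon is drawn S in compound 2 and R in compound 4. Among the compounds with values here, no step between two measured compounds shows what such a change does here. With nothing to guide the direction, the step from compound 2 to compound 4 is expected to stay within the scatter, that is a 1.3-fold higher number from compound 2 to compound 4 (0.11 log units; within the scatter). Compound 4 is therefore estimated at 20000 nM, between 8000 nM and 50000 nM.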

Compound 4, half-maximal inhibitory concentration: 25500 nM
Estimate against measurement, compound 4: 1.3-fold (0.11 log units) below; the range from low to high includes it.
By their numbers in this assay, from the lowest: compounds 2, 1, 4 and 3 (each within the scatter of the next).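

In this assay, within the data shown here, changing configuration alone gives a 1.6-fold higher number from compound 2 to compound 4 (0.21 log units; within the scatter) and so offers the first measured step in this set. Even with the saturated chain carbon and saturated ring carbons redrawn together, the two mirror-like drawings cannot be told apart beyond the scatter. The comparison is clean, as nothing else separates the pair: the fact that compounds 2 and 4 differ only in the configuration as drawn

As far as these compounds go, these centres all changed at once, so what any single stereocentre does on its own stays open. From the compounds shown here alone, whether an amine in place of the cinnamate ester would alter the number also remains open.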